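A few compounds are considered here, and "the series" means these few. Any claim that something is new, unique, unknown or untested is made for them only; others in the source may bear on it.

Measured so far in this series:
compound 1 `O=C(NCCNC(=O)c1cc2ccc(OCc3ccccc3)cc2oc1=O)c1cc2ccc(OCc3ccccc3)cc2oc1=O`: 15900 nM
compound 2 `CCN(CC)c1ccc2cc(C(=O)NC3CC3)c(=O)oc2c1`: > 100000 nM, a limit only
compound 3 `CCCOc1ccc2cc(C(=O)NN)c(=O)oc2c1`: 69800 nM

In a functional assay on HCT-116 cells (Homo sapiens) for cytotoxicity, read by MTT assay, with a stated time of 72 h (a higher number here means a weaker inhibitor, a lower number a stronger inhibitor), compound 1 gives 15900 nM and compound 3 gives 69800 nM. For compound 2 the assay reports no number, only the limit > 100000 nM; compound 2 therefore stands at the edge of the measured range, where (the limit of > 100000 nM in this assay, at which 1 of the 3 values shown sits). Compound 4 `CCN(CC)c1ccc2cc(C(=O)N/N=C(/C)c3cccnc3)c(=O)oc2c1` differs from compound 2 in one place: a group of 9 heavy atoms (7 carbon, 2 nitrogen; one six-membered aromatic ring with 1 hetero atom) in place of a group of 3 heavy atoms (3 carbon; one three-membered non-aromatic ring of carbon only), on an amide-type nitrogen. Among the measured compounds shown here, no measured pair shares this change, so the size of the step is open; since the starting point is a limit, only a move toward stronger inhibition could show up as a number. Compound 3 reaches a measurable 69800 nM, so a comparable value appears plausible. Compound 4 is expected near 40000 nM, within 10000 nM to 150000 nM, which would mean an expected step of an at least 2.5-fold lower number from compound 2 to compound 4 (0.39 log units; beyond the scatter).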

Compound 4, half-maximal inhibitory concentration: > 100000 nM
Compound 4: only a limit was reported; the forecaster's own chance of this, stated with the estimate: 35%; at least 2.5-fold (0.39 log units) between middle value and limit.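

No step can be read from compound 2 to compound 4, since both are reported only as limits: the limit of > 100000 nM in this assay, at which 2 of the 4 values shown sit. The compounds shown leave open whether the group with the six-membered aromatic ring, in place of cyclopropyl on the amide-type nitrogen, changes cytotoxicity at all.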